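A few compounds are considered here, and "the series" means these few. Any claim that something is new, unique, unknown or untested is made for them only; others in the source may bear on it.

Of the compounds shown here, three have been measured in an assay on isolated protein for inhibition of liver carboxylesterase 1 (Homo sapiens), with a stated time of 24 h; a lower number here means a stronger inhibitor, a higher number a weaker inhibitor. Compound 1, `CCCCCC[S+]([O-])CC(O)(O)C(F)(F)F`, gives 3.31 nM. Compound 2, `CCCCCCCC[S+]([O-])CC(O)(O)C(F)(F)F`, gives 0.603 nM. Compound 3, `CCCCCCS(=O)(=O)CC(O)(O)C(F)(F)F`, gives 0.708 nM. Compound 2 and compound 3 sit within the usual scatter of one another, and both lie well below compound 1: the step of a 5.5-fold lower number from compound 1 to compound 2 (0.74 log units; beyond the scatter) is the only one here that goes beyond the scatter, and it came from ethyl in place of hydrogen on a saturated chain carbon, six bonds along the chain from a sulfur.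

Compound 4, `CCCCCCCCCC[S+]([O-])CC(O)(O)C(F)(F)F`, carries that same kind of change one stage further: ethyl in place of hydrogen on a saturated chain carbon, eight bonds along the chain from a sulfur. Going by the values given here, the one measured step that bears on it is a 5.5-fold lower number from compound 1 to compound 2 (0.74 log units; beyond the scatter). If lengthening the chain again acts in the same direction, a further drop would be expected, though there is no second step to say whether the gain continues at full size or levels off. The step is therefore expected to be a 2.0-fold lower number from compound 2 to compound 4 (0.30 log units; within the scatter), smaller than the earlier one. Compound 4 is estimated at 0.3 nM, with a likely range from 0.1 nM to 1 nM.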

Compound 4, inhibition constant: 0.501 nM
Compound 4: middle estimate off by 1.7-fold (0.22 log units), on the low side; low and high end bracket the measured number.
By their numbers in this assay, from the lowest: compounds 4, 2 and 3 (each within the scatter of the next); then compound 1.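

In this assay, adding ethyl on a saturated chain carbon, eight bonds along the chain from a sulfur, gives a 1.2-fold lower number from compound 2 to compound 4 (0.08 log units; within the scatter), so this further lengthening cannot be told apart from no change, whereas the same kind of change closer in gave a 5.5-fold lower number from compound 1 to compound 2 (0.74 log units; beyond the scatter). The overall gain from the longest chain, a 6.6-fold lower number from compound 1 to compound 4 (0.82 log units; beyond the scatter), is therefore already in hand at compound 2, and among these compounds the benefit of added chain length does not visibly continue past that point. No measurement shown here accounts for this levelling off.

On these data alone, it remains open whether a still longer chain would hold this level or lose it, and whether an amine or a carboxylic acid at the chain end would be tolerated. As far as these compounds go, the sulfur form of compound 3 also remains untested here in combination with the longer chains of compound 2 and compound 4.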